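A few compounds are considered here, and "the series" means these few. Any claim that something is new, unique, unknown or untested is made for them only; others in the source may bear on it.

Working notes on the series. Among the compounds with values here, in a functional assay on A549 cells (Homo sapiens) for inhibition, read by CCK-8 assay, with a stated time of 72 h, tested at 8 uM (on this read-out lower numbers stand for less inhibition of growth and higher numbers for more inhibition of growth at the one concentration tested), compound 1 (`Nc1ccccc1NC(=O)/C=C/c1ccc(CSc2ccc(Cl)cc2)cc1`) gives 59.6%, the lower of the two numbers measured so far. Compound 2 (`Nc1ccccc1NC(=O)c1ccc(CSc2cccc(F)c2)cc1`) gives 72.7%, and the gap between these two values lies beyond the usual scatter. Within the data shown here, with only two values, the position of compound 1 says little about the range the series can reach.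

Compound 3 (`Nc1ccccc1NC(=O)/C=C/c1ccc(CSc2ccc(F)cc2)cc1`) has not yet been measured in this assay. It comes from compound 1 by placing fluoro in place of chloro on an aromatic carbon, para to a large group, so that 4-chlorophenyl becomes 4-fluorophenyl: fluoro in place of chloro on an aromatic carbon. The rest of the structure stays the same.

Among the measured compounds shown here, no two measured compounds differ in one place only, so the data give no direct measure of this exchange. The expectation therefore starts from compound 1 at 59.6%, with no firm direction and no shift beyond the scatter. The expected change is a number 2.4 percentage points higher from compound 1 to compound 3 (within the scatter). For compound 3 the estimated value is 62%, with an expected range from 47% to 77%.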

Compound 3, percent growth inhibition at one concentration: 59.1%
Beside the measured number, compound 3's estimate is 2.9 percentage points above it; the range from low to high includes it.
By their numbers in this assay, from the lowest: compounds 3 and 1 (each within the scatter of the next); then compound 2.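

Fluoro in place of chloro on an aromatic carbon, para to a large group, gives a number 0.5 percentage points lower from compound 1 to compound 3 (within the scatter) in this assay and is the first step in the series that can be read at a single place. Within this pair, 4-chlorophenyl and 4-fluorophenyl read alike at the one concentration tested, so on this read-out the exchange of these two halogens at this position does not separate the compounds. No independent measurement is at hand that could explain this result.

Within the data shown here, compound 2 differs from compound 1 and from compound 3 in more than one place, so its steps to them cannot be read, and the one step available covers only a swap between two halogens. As far as these compounds go, whether a group of another kind at this position, such as methoxy, an amine or a carboxylic acid, would leave the growth inhibition in the same range remains open, as does the reading for a plain phenyl with no group there.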